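Moving the Hydroxyl on One Phenyl Ring

The compounds below may be only part of what the source reports. "The series", "measured", "known", "first", "only" and "open" are said of these compounds alone.

Three compounds sharing one core were tested in an assay on isolated protein for inhibition of DNA topoisomerase 1 (Homo sapiens), with a stated time of 30 min, tested at 20 uM; a higher number here means a stronger effect of the compound at the concentration tested, a lower number a weaker effect. Compound 1 `Oc1ccc(-c2cc(-c3cccs3)cc(-c3ccc(O)cc3)n2)cc1` gives 0.9%. Compound 2 `Oc1ccc(-c2cc(-c3ccsc3)cc(-c3ccc(O)cc3)n2)cc1` gives 7.5%. Compound 3 `Oc1ccc(-c2cc(-c3ccoc3)cc(-c3cccc(O)c3)n2)cc1` gives 1.3%. On these three numbers compound 3 stands second highest, though all three lie within the scatter of one another. Among the measured compounds shown here, the only step between compounds that differ in one place is a number 6.6 percentage points higher from compound 1 to compound 2 (within the scatter), and that step swaps thiophen-2-yl for thiophen-3-yl rather than touching the 3-hydroxyphenyl group.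

Compound 4 `Oc1ccc(-c2cc(-c3ccoc3)cc(-c3ccc(O)cc3)n2)cc1` has not yet been measured. It differs from compound 3 in one place: 4-hydroxyphenyl in place of 3-hydroxyphenyl on an aromatic carbon. For the measured compounds named here, no measured pair isolates this change, so the step from compound 1 to compound 2 bears on it only as a sign that a single swap of an aromatic group on this core left the number within the scatter. The expected step is therefore a number 1.7 percentage points higher from compound 3 to compound 4 (within the scatter), nothing beyond the scatter. The estimate for compound 4 in this assay is 3%, expected to fall between 0% and 12%.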

Compound 4, a percentage reported as inhibition, at one concentration (the size of the read-out at that concentration, not a potency): 0%
Compound 4: middle estimate off by 3 percentage points, on the high side; measured number inside the range.
By their numbers in this assay, from the lowest: compounds 4, 1, 3 and 2 (each within the scatter of the next).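

Compound 3 and compound 4 isolate the hydroxyl move on the phenyl ring next to the ring nitrogen, and in this assay exchanging 3-hydroxyphenyl for 4-hydroxyphenyl gives a number 1.3 percentage points lower from compound 3 to compound 4 (within the scatter) and no separation between the two. With 4-hydroxyphenyl on both sides, the other aromatic group can also be compared, giving a number 7.5 percentage points lower from compound 2 to compound 4 (within the scatter) for one exchange and a number 0.9 percentage points lower from compound 1 to compound 4 (within the scatter) for the other, so neither thiophene differs measurably from furan-3-yl here. No available evidence offers an explanation for these numbers.

The compounds shown leave open whether any change at this position can move the number beyond the scatter in this assay at all. As far as these compounds go, an amine or a carboxylic acid in place of the hydroxyl remains untested among them, as does a longer chain on that phenyl ring.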